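This account rests on a few compounds, and the source may have more. Where it says the series, first, only, none or still open, it means among the compounds named here.

Compound 1 `O=C(COc1ccc(C(=O)/C=C/c2ccccc2Br)cc1)N[C@H]1CCOC1=O`: 12200 nM
Compound 2 `CC(C)c1ccc(NCC(=O)N[C@H]2CCOC2=O)cc1`: > 64000 nM
Compound 3 `O=C(CNc1cccc(Cl)c1)N[C@H]1CCOC1=O`: > 64000 nM

Of the compounds shown here, three have so far been measured in a functional assay on MGC-803 cells (Homo sapiens) for antiproliferative activity, read by MTT assay, with a stated time of 72 h; a higher number here means a weaker inhibitor, a lower number a stronger inhibitor. Within the data shown here, compound 1 gives 12200 nM, which is the only plain number among them. For compound 2 the reading is a limit of the assay, > 64000 nM. For compound 3 the reading is likewise a limit, > 64000 nM. Compound 1 therefore stands alone as the compound with a measured number, while the other two sit at the limit of > 64000 nM in this assay, at which 2 of the 3 values shown sit.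

The next compound, compound 4 `O=C(COc1ccc(C(=O)/C=C/c2ccccc2)cc1)N[C@H]1CCOC1=O`, has not yet been measured. It differs from compound 1 in one place: hydrogen in place of bromo on an aromatic carbon. Among the measured compounds shown here, no pair of measured compounds differs in just one place, so nothing in the numbers shows directly how such a change shifts the reading. The change is small, a single heavy atom giving way to a hydrogen, so only a modest shift in this assay is expected, most likely toward a weaker inhibitor and possibly not beyond the usual scatter. The estimate for compound 4 is 20000 nM, between 6000 nM and 60000 nM, with the expected step being a 1.6-fold higher number from compound 1 to compound 4 (0.21 log units; within the scatter).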

Compound 4, half-maximal inhibitory concentration: > 64000 nM
Compound 4 was reported as a limit; the forecaster's own chance of this, stated with the estimate: 15%; at least 3.2-fold (0.50 log units) between middle value and limit.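

Hydrogen in place of bromo on this aromatic carbon, ortho to a large group, is the first single change that can be read in this assay and the step is an at least 5.2-fold higher number from compound 1 to compound 4 (0.71 log units; beyond the scatter) toward a weaker inhibitor. Within this pair, the 2-bromophenyl end therefore matters: the compound carrying the bromo gives a plain number, whereas the one with a simple phenyl does not. Compound 4 is reported only as a limit, so the step gives a smallest possible size and not an exact one, and compound 4 joins the compounds sitting at the same limit: the limit of > 64000 nM in this assay, at which 3 of the 4 values shown sit.

As far as these compounds go, what remains open is whether bromo is special or whether other groups on this carbon, such as chloro, methyl, methoxy or an amine, would also keep a measurable reading, and whether bromo on another carbon of the same ring would do the same. The compounds shown also give no reason for the step, and compound 2 and compound 3 differ from compound 1 in more than one place, so they cannot settle either question.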